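The source may report more compounds than this note shows. Statements on the series, on what has been measured and on what is new or still open speak of the compounds shown alone.

Measured in a functional assay on the whole organism (Abdomen, strain ddY) for inhibition, with Mus musculus as the target, with stated times of 30 min and 20 min; a lower number here means that less compound is needed, a higher number that more compound is needed for the effect:
Compound 1 `Cn1ncc(O)c(Cl)c1=O`: > 100 mg/kg (a limit)
Compound 2 `CCCNc1cnn(C)c(=O)c1OCC`: 72 mg/kg
Compound 3 `CCOc1c(Nc2ccccc2)cnn(C)c1=O`: 36 mg/kg

The reading for compound 1 is a limit and not a number, (the limit of > 100 mg/kg in this assay, at which 1 of the 3 values shown sits). Only compound 2 and compound 3 carry numbers, and these two lie within the scatter of each other: a 2.0-fold lower number from compound 2 to compound 3 (0.30 log units; within the scatter). Compound 2 therefore has no measured neighbour that clearly separates from it.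

Compound 4 `CCOc1ccnn(C)c1=O` follows from compound 2 by one change, hydrogen in place of propylamino on an aromatic carbon. Among the compounds with values here, the one measured step that bears on this, a 2.0-fold lower number from compound 2 to compound 3 (0.30 log units; within the scatter), only exchanges the group on the nitrogen, and it stays within the scatter. It does not show what happens when the whole propylamino leaves, so the guidance is weak. A small move toward a higher number is expected, with no firm step beyond the scatter, and a limit reading remains possible. The estimated change is a 1.3-fold higher number from compound 2 to compound 4 (0.10 log units; within the scatter). Compound 4 is expected at 90 mg/kg, with an estimated range of 40 mg/kg to 200 mg/kg.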

Compound 4, dose for half-maximal effect: > 100 mg/kg
Compound 4 gave a limit, no number; the forecaster's own chance of this, stated with the estimate: 35%; middle value at least 1.1-fold (0.04 log units) away from the limit.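

Within the data shown here, with hydrogen in place of propylamino on the aromatic carbon, this assay gives an at least 1.3-fold higher number from compound 2 to compound 4 (0.14 log units; that floor lies within the scatter), the first reading on this position itself, since the earlier step only exchanged the group on the nitrogen. As the reading of compound 4 is a limit, this step gives only a floor, and the data do not separate compound 4 clearly from compound 2. The reading of compound 4 is a limit, and it joins compound 1 at that limit: the limit of > 100 mg/kg in this assay, at which 2 of the 4 values shown sit.

On these data alone, how far the true value of compound 4 lies from that of compound 2 remains open. Also open, as far as these compounds go, is whether a plain amino group, or a longer chain such as butyl on the nitrogen, would give a reading clearly apart from compound 2 and compound 3.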